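Ring swap at compound 1: three hetero atoms to one

This account rests on a few compounds, and the source may have more. Where it says the series, first, only, none or still open, it means among the compounds named here.

Measured so far in an in vitro functional assay on cells (Fibroblast) for agonist activity at Alpha-1B adrenergic receptor (Homo sapiens); on this read-out lower numbers stand for an effect already at smaller amounts and higher numbers for an effect only at larger amounts of compound:
compound 1, `Cn1ncnc1-c1ccccc1NCC1=NCCN1`, 39.8 nM
compound 2, `CCCn1ncnc1-c1ccccc1NCC1=NCCN1`, 316 nM
Not yet measured: compound 3, `Cn1cccc1-c1ccccc1NCC1=NCCN1`

Compound 1 stands at the lowest of the two numbers in this assay; its nearest neighbour is compound 2, and the step of a 7.9-fold higher number from compound 1 to compound 2 (0.90 log units; beyond the scatter) is beyond the scatter. That step is the only one measured, and it sits on the saturated chain carbon bound to an aromatic nitrogen, not on the five-membered ring itself.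

Compound 3 differs from compound 1 as follows: 1-methyl-1H-pyrrol-2-yl in place of 1-methyl-1H-1,2,4-triazol-5-yl on an aromatic carbon. The counted change keeps the heavy-atom number but drops from 3 hydrogen-bond acceptors to 1. Among the measured compounds shown here, no measured pair alters this ring, so the step from compound 1 to compound 2 bears on it only as a sign that changes at the periphery of the shared core can cost potency in this assay.

For compound 3 a modest upward move is expected, a 2.5-fold higher number from compound 1 to compound 3 (0.40 log units; beyond the scatter), with wide uncertainty. The estimate for compound 3 is 100 nM, within 25 nM to 500 nM.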

Compound 3, half-maximal effective concentration: < 100000 nM
Compound 3 ended at the assay's limit; the forecaster's own chance of this, stated with the estimate: 5%; the middle value lies beyond the limit too.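

In this assay compound 3 gives < 100000 nM, which is a limit of the assay and not a number. No step between compound 1 and compound 3 can be read, because the result for compound 3 is such a limit: the limit of < 100000 nM in this assay, at which 1 of the 3 values shown sits.

The compounds shown leave open the size and direction of the change when 1-methyl-1H-pyrrol-2-yl replaces 1-methyl-1H-1,2,4-triazol-5-yl.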